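Trading one halogen-bearing aryl ring for another

The compounds below may be only part of what the source reports. "The series", "measured", "known", "first", "only" and "open" are said of these compounds alone.

Three compounds share one core and differ only in the aryl group on the ring nitrogen. Compound 1 `CCOC(=O)c1c(-c2cc3ccccc3oc2=O)nn(-c2ccc(C)c(C)c2)c1C(=O)OCC` carries a 3,4-dimethylphenyl there, compound 2 `CCOC(=O)c1c(-c2cc3ccccc3oc2=O)nn(-c2ccc(OC)cc2)c1C(=O)OCC` a 4-methoxyphenyl, and compound 3 `CCOC(=O)c1c(-c2cc3ccccc3oc2=O)nn(-c2cccc(Cl)c2)c1C(=O)OCC` a 3-chlorophenyl. In a functional assay on A549 cells (Homo sapiens) for cytotoxicity, read by MTT assay, with a stated time of 48 h (a higher number here means a weaker inhibitor, a lower number a stronger inhibitor), compound 1 gives 52000 nM, compound 2 gives 86000 nM and compound 3 gives 28000 nM. Compound 3 has the lowest of the three numbers; the step of a 1.9-fold lower number from compound 1 to compound 3 (0.27 log units; within the scatter) stays within the scatter, while the step of a 3.1-fold lower number from compound 2 to compound 3 (0.49 log units; beyond the scatter) is modest but real. Compound 4 `CCOC(=O)c1c(-c2cc3ccccc3oc2=O)nn(-c2ccc(Br)cc2)c1C(=O)OCC` differs from compound 3 in one place: 4-bromophenyl in place of 3-chlorophenyl on an aromatic nitrogen. Among the measured compounds shown here, no measured step swaps one halogen-bearing ring for another, and the aryl changes seen so far moved this assay only a little, so the expected step of a 1.1-fold higher number from compound 3 to compound 4 (0.06 log units; within the scatter) is none beyond the scatter. Compound 4 is therefore estimated at 32000 nM, with a range from 13000 nM to 80000 nM.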

Compound 4, half-maximal inhibitory concentration: 100000 nM
Compound 4: middle estimate off by 3.1-fold (0.49 log units), on the low side; measured number outside the range, above it.
By their numbers in this assay, from the lowest: compounds 3, 1, 2 and 4 (each within the scatter of the next, the first and the last beyond it).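

In this assay, the change from 3-chlorophenyl to 4-bromophenyl on the aromatic nitrogen gives a 3.6-fold higher number from compound 3 to compound 4 (0.55 log units; beyond the scatter), so a halogen on this ring does not by itself keep the number low. Compound 4 does not stand apart from the rings without halogen: a 1.2-fold higher number from compound 2 to compound 4 (0.07 log units; within the scatter) and a 1.9-fold higher number from compound 1 to compound 4 (0.28 log units; within the scatter) both stay within the scatter, leaving compound 3 as the only one of the four clearly apart from compound 2 and compound 4. Nothing available explains why the two halogen-bearing rings differ.

This step changes both the halogen and its place on the ring, so its effect cannot be assigned to either one; 4-chlorophenyl and 3-bromophenyl would separate the two. Also open, as far as these compounds go, is how an unsubstituted phenyl, or a phenyl carrying an amine or a carboxylic acid, would read in this assay.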